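Configuration change in a flat methoxy series

The source may hold more compounds than are shown below. What is called first, only, known or untested is meant among the compounds shown, and "the series" means these compounds.

Compound 1 `COc1ccc([C@H](O)[C@H]2CO[C@@H](c3ccc(OC)c(OC)c3)[C@H](C/C=C/c3ccccc3)C2)cc1OC`: 16100 nM
Compound 2 `COc1ccc(/C=C/C[C@@H]2C[C@@H]([C@@H](O)c3ccc(OC)c(OC)c3)CO[C@H]2c2ccc(OC)c(OC)c2)cc1`: 17100 nM
Compound 3 `COc1cccc(/C=C/C[C@@H]2C[C@@H]([C@@H](O)c3ccc(OC)c(OC)c3)CO[C@H]2c2ccc(OC)c(OC)c2)c1`: 16400 nM

All three values come from a functional assay on HeLa cells (Homo sapiens) for cytotoxicity, read by WST assay, with a stated time of 48 h; a lower number here means a stronger inhibitor, a higher number a weaker inhibitor. Compound 1 stands within the scatter of both other compounds, so the three cannot be ordered on these numbers.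

Compound 4 `COc1ccc([C@H]2OC[C@H]([C@@H](O)c3ccc(OC)c(OC)c3)C[C@@H]2C/C=C/c2ccccc2)cc1OC` is the next compound to compare with compound 1. The structural difference is the two compounds have the same atoms and bonds and differ only in configuration as drawn: 2 of 5 stereo elements differ; a stereocentre at a saturated ring carbon is drawn R in compound 1 and S in compound 4; a stereocentre at a saturated ring carbon is drawn R in compound 1 and S in compound 4.

The measured steps are a 1.1-fold higher number from compound 1 to compound 2 (0.03 log units; within the scatter), a 1.0-fold higher number from compound 1 to compound 3 (0.01 log units; within the scatter) and a 1.0-fold lower number from compound 2 to compound 3 (0.02 log units; within the scatter). They concern only the addition or relocation of a methoxy group on an aromatic ring. None of them changes configuration, so the series holds no direct measurement of a change of this kind, and they bear on it only indirectly. No step beyond the scatter is therefore expected in this assay, and neither direction is favoured, but the range is kept wide because of this gap.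

The expected step is a 1.0-fold lower number from compound 1 to compound 4 (0.00 log units; within the scatter). The estimate for compound 4 is 16000 nM, with an expected range of 7000 nM to 32000 nM.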

Compound 4, half-maximal inhibitory concentration: 14800 nM
The estimate for compound 4 lay 1.1-fold (0.03 log units) above the measured number; measured number inside the range.
By their numbers in this assay, from the lowest: compounds 4, 1, 3 and 2 (each within the scatter of the next).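

In this assay, changing two stereocentres at saturated ring carbons from R in compound 1 to S in compound 4 gives a 1.1-fold lower number from compound 1 to compound 4 (0.04 log units; within the scatter). The earlier steps shown here concerned only a methoxy group on an aromatic ring, whereas this pair tests configuration directly: the fact that compounds 1 and 4 differ only in the configuration as drawn. For this pair, the change of both stereocentres together produces no step beyond the scatter, so the two drawn configurations cannot be told apart in this assay.

The compounds shown leave open how either stereocentre behaves when changed alone, and whether the same holds for the methoxy-bearing styryl-type chains of compound 2 and compound 3. On these data alone, it is also open whether configuration would matter in a compound carrying an amine in place of the hydroxy group.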